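This account rests on a few compounds, and the source may have more. Where it says the series, first, only, none or still open, it means among the compounds named here.

Of the compounds shown here, two have so far been tested in a functional assay on MDA-MB-231 cells (Homo sapiens) for antiproliferative activity, read by MTT assay, with a stated time of 72 h; a lower number here means a stronger inhibitor, a higher number a weaker inhibitor. Compound 1 `O=C(Nc1ccc(-c2noc(-c3cccc(NS(=O)(=O)c4cccc(Cl)c4)c3)n2)c(Cl)c1)c1cccnc1` gives > 10000 nM, which is a limit of the assay rather than a measured number. Compound 2 `O=C(Nc1ccccc1)Nc1cccc(-c2nc(-c3ccc(NC(=O)c4cccnc4)cc3Cl)no2)c1` gives > 10000 nM in this assay, again only a limit. Among the compounds with values here, the single measured step, a step that the two limits leave unreadable from compound 1 to compound 2, therefore cannot be read in size or direction, since both of its ends sit at the limit of > 10000 nM in this assay, at which 2 of the 2 values shown sit. Compound 3 `O=C(Nc1cccc(-c2nc(-c3ccc(NC(=O)c4cccnc4)cc3Cl)no2)c1)Nc1ccc(Cl)c(C(F)(F)F)c1` has not yet been measured; it differs from compound 2 by 4-chloro-3-(trifluoromethyl)phenyl in place of phenyl on an amide-type nitrogen. Within the data shown here, no measured step bears on this change: the one step that exists concerns a different part of the shared core and is itself unreadable. Nothing shown, then, points to a step beyond the scatter in either direction, and the only firm fact is that compound 2 stands at the limit. The step is estimated as an at least 1.4-fold lower number from compound 2 to compound 3 (0.15 log units; that floor lies within the scatter), with little confidence. Compound 3 is expected to give about 7000 nM in this assay, within a range from 1000 nM to 30000 nM, and the result may well again be reported only as a limit.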

Compound 3, half-maximal inhibitory concentration: 1900 nM
Compound 3: the middle estimate sits 3.7-fold (0.57 log units) above what was measured; low and high end bracket the measured number.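

The ring on the amide-type nitrogen is the first place shown where a change lifts a compound off the limit of the assay: in this assay, 4-chloro-3-(trifluoromethyl)phenyl in place of phenyl gives an at least 5.2-fold lower number from compound 2 to compound 3 (0.72 log units; beyond the scatter). The ring stays a six-membered aromatic ring of carbon, and the count of hydrogen-bond donors and acceptors in the group stays the same, so the gain goes with the chloro and trifluoromethyl substituents added to that ring, though the data do not say how. Its size is only a floor, and the true gap could be larger, since compound 2 stands at a limit rather than a measured number: the limit of > 10000 nM in this assay, at which 2 of the 3 values shown sit.

The compounds shown do not separate the chloro from the trifluoromethyl group, so a ring carrying only one of them, or a methoxy group or a nitrile in their place, would be needed to tell which matters. As far as these compounds go, the step from compound 1 to compound 2 cannot be read, so it also stays open whether the same substituted ring would help with the sulfonyl link of compound 1.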